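Removing the Amino Group from a Sugar-Bearing Fused Heterocycle

The source may hold more compounds than are shown below. What is called first, only, known or untested is meant among the compounds shown, and "the series" means these compounds.

In a functional assay on CEM-DNR-bulk cells (Homo sapiens), read by MTT assay, with a stated time of 72 h (on this read-out lower numbers stand for stronger inhibition and higher numbers for weaker inhibition), compound 3 `COc1nc(N)nc2c1c(-c1ccco1)cn2[C@@H]1O[C@H](CO)[C@@H](O)[C@H]1O` reaches only the limit > 20000 nM, so no exact number exists for it. Compound 1 `COc1ncnc2c1c(-c1ccoc1)cn2[C@@H]1O[C@H](CO)[C@@H](O)[C@H]1O` likewise stops at the limit > 20000 nM. Compound 2 `COc1ncnc2c1c(-c1cccs1)cn2[C@@H]1O[C@H](CO)[C@@H](O)[C@H]1O` gives 12100 nM. The step of an at least 1.6-fold lower number from compound 1 to compound 2 (0.21 log units; that floor lies within the scatter) changes a different part of the molecule and so offers no direct guide to the change considered here. Compound 4 `COc1ncnc2c1c(-c1ccco1)cn2[C@@H]1O[C@H](CO)[C@@H](O)[C@H]1O` differs from compound 3 by hydrogen in place of amino on an aromatic carbon. Among the compounds with values here, no measured step covers this change, but the limit of > 20000 nM in this assay, at which 2 of the 3 values shown sit, shows weak inhibition with and without the amino group. The step of a number no higher from compound 3 to compound 4 (the limit leaves the size open) is therefore expected to stay within the scatter. Compound 4 is estimated at 20000 nM, with a range from 8000 nM to 50000 nM.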

Compound 4, half-maximal inhibitory concentration: 160 nM
The estimate for compound 4 lay 130-fold (2.10 log units) above the measured number, outside the stated range (below it).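

In this assay the position between two ring nitrogen atoms proves sensitive: hydrogen in place of amino gives an at least 120-fold lower number from compound 3 to compound 4 (2.09 log units; beyond the scatter) and turns a weak compound into a strong one. The attached ring matters as well, with a 76-fold lower number from compound 2 to compound 4 (1.88 log units; beyond the scatter) and then an at least 120-fold lower number from compound 1 to compound 4 (2.09 log units; beyond the scatter) on the same core. Among the compounds shown, strong inhibition appears only where hydrogen at this position and furan-2-yl occur together.

Going by these compounds, the full size of two of these steps stays open, as each has a limit at one end: the limit of > 20000 nM in this assay, at which 2 of the 4 values shown sit. On these data alone, whether a methyl group or a fluorine atom at this position would also keep the number low remains open too.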